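A few compounds are considered here, and "the series" means these few. Any claim that something is new, unique, unknown or untested is made for them only; others in the source may bear on it.

Compound 2 `Cc1ccc(S(=O)(=O)NCC(=O)N[C@@H](C)C(=O)N[C@@H](CC(C)C)C(=O)N[C@@H](CCCC[N+](C)(C)C)C(=O)N[C@@H](CO)C(N)=O)cc1` gives 34000 nM in an assay on isolated protein for displacement of a labelled ligand from Chromobox protein homolog 7 (Homo sapiens), read by fluorescence polarization, with a stated time of 15 min (a higher number here means a weaker inhibitor, a lower number a stronger inhibitor), one of just two numbers in this assay, and compound 1 `CC(C)C[C@H](NC(=O)[C@H](C)NC(=O)CNC(=O)c1ccccc1)C(=O)N[C@@H](CCCC[N+](C)(C)C)C(=O)N[C@@H](CO)C(N)=O` gives 58000 nM in this assay, so the two lie within the scatter of each other. Compound 3 `CC(C)C[C@H](NC(=O)[C@H](C)NC(=O)CNS(=O)(=O)c1ccc(C(=O)O)cc1)C(=O)N[C@@H](CCCC[N+](C)(C)C)C(=O)N[C@@H](CO)C(N)=O` differs from compound 2 by carboxy in place of methyl on an aromatic carbon. Among the measured compounds shown here, no measured step exchanges methyl for carboxy; the only measured step, a 1.7-fold lower number from compound 1 to compound 2 (0.23 log units; within the scatter), stayed within the scatter, so for compound 3 no step beyond the scatter is expected. The expected step from compound 2 to compound 3 is no change at the digits printed from compound 2 to compound 3 (within the scatter). Compound 3 is estimated at 34000 nM, with a range from 12000 nM to 100000 nM.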

Compound 3, half-maximal inhibitory concentration: 53000 nM
Compound 3: the middle estimate sits 1.6-fold (0.19 log units) below what was measured; the measured number falls inside the stated range.
By their numbers in this assay, from the lowest: compounds 2, 3 and 1 (each within the scatter of the next).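

In this assay, the para position of this aromatic ring now carries carboxy as well as methyl, with a 1.6-fold higher number from compound 2 to compound 3 (0.19 log units; within the scatter), so a group of three heavy atoms with a hydrogen-bond donor changes nothing beyond the scatter. Replacing benzoyl with (4-carboxyphenyl)sulfonyl gives a 1.1-fold lower number from compound 1 to compound 3 (0.04 log units; within the scatter), so this larger exchange also stays within the scatter. No measurement here offers an explanation for this result.

Since no change shown so far moves the number beyond the scatter, what this position can tolerate remains open. An amine or a longer chain at this position could still give a different answer.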